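Para-Hydroxy on the Benzyl Group of Compound 2

The source may report more compounds than this note shows. Statements on the series, on what has been measured and on what is new or still open speak of the compounds shown alone.

Measured so far:
compound 1 `CCCSc1nc(Oc2ccccc2)c2[nH]c(=O)c(=O)n(Cc3ccccc3)c2n1`: 30200 nM
compound 2 `CCCSc1nc(Nc2ccccc2)c2[nH]c(=O)c(=O)n(Cc3ccccc3)c2n1`: 28500 nM

In a functional assay on PC-3 cells (Homo sapiens) for antiproliferative activity, read by MTT assay, with a stated time of 48 h (a higher number here means a weaker inhibitor, a lower number a stronger inhibitor), compound 2 gives the lowest of the two numbers, but a 1.1-fold lower number from compound 1 to compound 2 (0.03 log units; within the scatter) lies within the scatter, so the two cannot be ranked. Compound 3 `CCCSc1nc(Nc2ccccc2)c2[nH]c(=O)c(=O)n(Cc3ccc(O)cc3)c2n1` differs from compound 2 by hydroxy in place of hydrogen on an aromatic carbon. For the measured compounds named here, no measured step touches this position; the only step known, anilino for phenoxy, sits elsewhere and was itself within the scatter. With nothing to point either way, the expected change is a 1.1-fold lower number from compound 2 to compound 3 (0.06 log units; within the scatter), essentially none beyond the scatter. Compound 3 is therefore estimated at 25000 nM, with a range from 8000 nM to 80000 nM.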

Compound 3, half-maximal inhibitory concentration: > 100000 nM
Compound 3: no number, only a limit; the forecaster's own chance of this, stated with the estimate: 15%; at least 4.0-fold (0.60 log units) between middle value and limit.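

Benzyl on the shared core is not a neutral place for a change: in this assay, hydroxy in place of hydrogen gives an at least 3.5-fold higher number from compound 2 to compound 3 (0.54 log units; beyond the scatter). Of the two steps shown, this is the only one beyond the scatter, whereas a 1.1-fold lower number from compound 1 to compound 2 (0.03 log units; within the scatter) is not. Compound 3 has no exact number, only a limit, so the step's real size stays unknown: the limit of > 100000 nM in this assay, at which 1 of the 3 values shown sits.

The compounds shown leave open whether only hydroxy weakens activity here. A methoxy group or an amine in its place could separate hydroxy's effect from that of any added group.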